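From cyclopropylmethyl to cyclobutyl on the aryl ether

The source may hold more compounds than are shown below. What is called first, only, known or untested is meant among the compounds shown, and "the series" means these compounds.

Compound 3 (`Nc1ccc2cccc(OCCC3CC3)c2n1`) carries a 2-cyclopropylethyl group on an oxygen on an aromatic ring of the shared core. Of the two numbers recorded in an assay on cells with melanin-concentrating hormone receptor 1 (Homo sapiens) as the target, read by radioligand binding (a higher number here means a weaker inhibitor, a lower number a stronger inhibitor), compound 3 gives 492 nM and compound 1 (`COCC(C)Oc1cccc2ccc(N)nc12`) gives 606 nM, a gap of a 1.2-fold lower number from compound 1 to compound 3 (0.09 log units; within the scatter) that sits within the scatter. Compound 2 (`CC#CCCOc1cccc2ccc(N)nc12`) reaches only a limit of this assay, > 2000 nM. The steps of an at least 3.3-fold higher number from compound 1 to compound 2 (0.51 log units; beyond the scatter) and an at least 4.0-fold lower number from compound 2 to compound 3 (0.60 log units; beyond the scatter) both rest on that limit (the limit of > 2000 nM in this assay, at which 1 of the 3 values shown sits). Compound 4 (`Nc1ccc2cccc(OCC3CCC3)c2n1`) differs from compound 3 by cyclobutyl in place of cyclopropylmethyl on a saturated chain carbon bound to an oxygen on an aromatic ring. Of the measured steps, only an at least 4.0-fold lower number from compound 2 to compound 3 (0.60 log units; beyond the scatter) touches the same chain carbon, and it exchanges a ring for an alkyne rather than one ring for another; the step of a 1.2-fold lower number from compound 1 to compound 3 (0.09 log units; within the scatter) shows two different ether groups giving numbers within the scatter. Compound 4 is therefore expected to stay close to compound 3, with an estimated step of a 1.0-fold higher number from compound 3 to compound 4 (0.01 log units; within the scatter). Compound 4 is estimated at 500 nM, with a range from 250 nM to 1000 nM.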

Compound 4, half-maximal inhibitory concentration: 432 nM
Beside the measured number, compound 4's estimate is 1.2-fold (0.06 log units) above it, and the stated range covers the measured number.
By their numbers in this assay, from the lowest: compounds 4, 3 and 1 (each within the scatter of the next). At a limit, above all of these: compound 2.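

Cyclopropylmethyl and cyclobutyl have the same atoms joined differently, and exchanging them gives a 1.1-fold lower number from compound 3 to compound 4 (0.06 log units; within the scatter) in this assay, so a three-membered and a four-membered ring read alike at this position. The other new step that yields a firm comparison, a 1.4-fold lower number from compound 1 to compound 4 (0.15 log units; within the scatter), places cyclobutylmethyl within the scatter of the 1-(methoxymethyl)ethyl ether as well, so compounds 1, 3 and 4 form one group, against which compound 2 stands apart. Only an at least 4.6-fold lower number from compound 2 to compound 4 (0.66 log units; beyond the scatter) lies beyond the scatter, and it rests on the limit of compound 2, not on a number: the limit of > 2000 nM in this assay, at which 1 of the 4 values shown sits.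

The compounds shown leave open whether a larger ring such as cyclopentyl or cyclohexyl, or a ring carrying a hydroxyl or an amine, would move the number beyond the scatter. On these data alone, it also stays open whether any other ether on this oxygen would separate from compounds 1, 3 and 4 towards a lower number.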